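The source may hold more compounds than are shown below. What is called first, only, known or untested is meant among the compounds shown, and "the series" means these compounds.

Measured so far in a functional assay on MCF7 cells (Homo sapiens) for cytotoxicity, read by MTT assay, with a stated time of 72 h; on this read-out higher numbers stand for weaker inhibition and lower numbers for stronger inhibition:

Compound 1 `Cc1nnc(SCc2cc(=O)c3ccccc3o2)s1` gives > 25000 nM, which is a limit of the assay rather than a number.
Compound 2 `Cc1cc(C)nc(SCc2cc(=O)c3ccccc3o2)n1` gives > 25000 nM, also a limit of the assay rather than a number.
Compound 3 `Cc1ccc2oc(CSc3nc(C)cc(C)n3)cc(=O)c2c1` gives > 25000 nM, again a limit of the assay rather than a number.

These three compounds share one part of their structure, a bicyclic system carrying a sulfur-linked arm, and differ in the ring at the far end of that arm. Compound 2 and compound 3 carry the same end ring; compound 3 differs from compound 2 by methyl in place of hydrogen on an aromatic carbon. The step that the two limits leave unreadable from compound 2 to compound 3 cannot be read as a size, since both ends of it sit at the limit of > 25000 nM in this assay, at which 3 of the 3 values shown sit. How the core of compound 1 differs from the core of compound 2 is not broken down here; the two simply differ by more than one place.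

Compound 4 `Cc1ccc2oc(CSc3nnc(C)s3)cc(=O)c2c1` has not yet been measured in this assay. It stands to compound 1 as compound 3 stands to compound 2: it differs from compound 1 by methyl in place of hydrogen on an aromatic carbon, the same change, made at the same kind of place. Since that change gave no readable step between compound 2 and compound 3, and since compound 1 itself gives only a limit, the expectation for compound 4 is the step that the limit leaves unreadable from compound 1 to compound 4, most likely ending again at the limit. Compound 4 is estimated at 30000 nM, expected between 10000 nM and 100000 nM.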

Compound 4, half-maximal inhibitory concentration: > 25000 nM
Compound 4: a limit, no number; the forecaster's own chance of this, stated with the estimate: 85%; the middle value lies beyond the limit too.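

Compound 1 and compound 4 both give only a limit of the assay, not a number, so the size of the step for methyl in place of hydrogen between them cannot be read: the limit of > 25000 nM in this assay, at which 4 of the 4 values shown sit.

The compounds shown leave open whether any change to the shared core or to the end ring would give a readable value at all.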